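The compounds below may be only part of what the source reports. "The series", "measured", "known", "first", "only" and "open" are said of these compounds alone.

Measured compounds:
compound 1, `CCCOCNc1n[n+]([O-])c2cc(OC)ccc2[n+]1[O-]`, 2810 nM
compound 2, `COCNc1n[n+]([O-])c2ccccc2[n+]1[O-]`, 7450 nM
compound 3, `CC(OCNc1n[n+]([O-])c2ccccc2[n+]1[O-])c1ccccc1`, 2710 nM

The three measured compounds share one core and differ only in the group on the oxygen of the side chain. In a functional assay on A549 cells (Homo sapiens) for cytotoxicity, read by MTT assay, with a stated time of 72 h (on this read-out lower numbers stand for stronger inhibition and higher numbers for weaker inhibition), compound 2 gives 7450 nM, the highest of the three numbers. Compound 1 gives 2810 nM and compound 3 gives 2710 nM; both lie lower than compound 2 by more than the scatter, while the two of them lie within the scatter of each other, so no order can be stated between compound 1 and compound 3.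

Compound 4, `CC(C)CCOCNc1n[n+]([O-])c2ccccc2[n+]1[O-]`, has not yet been measured in this assay. It differs from compound 2 in one place: isobutyl in place of hydrogen on a saturated chain carbon bound to an oxygen on a saturated carbon. In the two measured cases where a larger group sits on that oxygen, compound 1 and compound 3, the numbers are lower than for compound 2. On that basis a step to a lower number is expected, beyond the scatter, of about the size seen between compound 2 and the other two. The expected step is a 2.5-fold lower number from compound 2 to compound 4 (0.40 log units; beyond the scatter). Compound 4 is estimated at 3000 nM, with a range from 1300 nM to 7500 nM.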

Compound 4, half-maximal inhibitory concentration: 7270 nM
Compound 4: the middle estimate sits 2.4-fold (0.38 log units) below what was measured, and the stated range covers the measured number.
By their numbers in this assay, from the lowest: compounds 3 and 1 (each within the scatter of the next); then compounds 4 and 2 (each within the scatter of the next).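

In this assay, within the data shown here, the change to isobutyl on a saturated chain carbon bound to an oxygen on a saturated carbon appears as a 1.0-fold lower number from compound 2 to compound 4 (0.01 log units; within the scatter), so this chain, larger than the one in compound 2 by the four carbons of the isobutyl group, leaves the number where it was. Among these compounds, this is the first direct reading at this position, and it shows that added saturated chain alone need not move the number, something the lower values of compound 1 and compound 3 could not show, as each of those differs from compound 2 in more than one place. Nothing shown explains why the step is so small.

What the compounds shown leave open is whether the lower numbers of compound 1 and compound 3 come from the methoxy group on the core of compound 1 and the phenyl ring of compound 3, or from something else in those structures. On these data alone, it also remains open how this position would respond to a group of another kind, such as an amine or a carboxylic acid at the end of the chain.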